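A Fluorine for a Methoxy Group on the Amide Arm

The compounds below may be only part of what the source reports. "The series", "measured", "known", "first", "only" and "open" are said of these compounds alone.

Compound 1 `CCOC(=O)C1=Cc2ccccc2OC1(OCc1cn(CC(=O)Nc2ccc(OC)cc2)nn1)C(F)(F)F` is the only one of the three measured compounds to give a number in a functional assay on A549 cells (Homo sapiens) for inhibition, read by MTT assay, with a stated time of 24 h; on this read-out lower numbers stand for stronger inhibition and higher numbers for weaker inhibition: compound 1 gives 29400 nM. Compound 2 `O=C(O)C1=Cc2ccccc2OC1(OCc1cc(-c2ccc([N+](=O)[O-])cc2)no1)C(F)(F)F` reaches only a limit of this assay, > 150000 nM. Compound 3 `O=C(O)C1=Cc2ccccc2OC1(OCc1cc(-c2ccc3ccccc3c2)no1)C(F)(F)F` likewise reaches only a limit, > 150000 nM. The step that the two limits leave unreadable from compound 2 to compound 3 therefore cannot be read, and it changes a different part of the shared core from the one at issue here; both compounds 2 and 3 sit at the limit of > 150000 nM in this assay, at which 2 of the 3 values shown sit.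

Compound 4 `CCOC(=O)C1=Cc2ccccc2OC1(OCc1cn(CC(=O)Nc2cccc(F)c2)nn1)C(F)(F)F` differs from compound 1 in one place: 3-fluorophenyl in place of 4-methoxyphenyl on an amide-type nitrogen. No measured step involves an exchange on that amide-type nitrogen, so nothing shown gives the direction or the size of the effect of this change. The expectation rests on compound 1 alone, with 29400 nM as the anchor. Compound 4 is therefore expected to show no step beyond the scatter, a 1.0-fold higher number from compound 1 to compound 4 (0.01 log units; within the scatter), and is estimated at 30000 nM, within a range of 10000 nM to 90000 nM.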

Compound 4, half-maximal inhibitory concentration: > 150000 nM
Compound 4: no number, only a limit; the forecaster's own chance of this, stated with the estimate: 15%; middle value at least 5.0-fold (0.69 log units) from the limit.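

This is the first exchange shown on the amide-type nitrogen, and it shows that the group held there is not a neutral choice: 3-fluorophenyl in place of 4-methoxyphenyl gives an at least 5.1-fold higher number from compound 1 to compound 4 (0.70 log units; beyond the scatter) in this assay. With the rest of the structure unchanged, this single exchange is enough to lose a readable number. Compound 4 reaches only a limit of the assay, > 150000 nM, so the step is a minimum and its true size cannot be read: the limit of > 150000 nM in this assay, at which 3 of the 4 values shown sit.

The compounds shown leave open whether the loss follows from removing the methoxy group, adding the fluorine, or moving the substituent on the ring, as all of these change together. A plain phenyl, a 4-fluorophenyl or a 3-methoxyphenyl group on that nitrogen would separate these possibilities.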